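The compounds below may be only part of what the source reports. "The series", "measured", "known", "first", "only" and "open" are said of these compounds alone.

Compound 3 `CCOc1ccccc1OC(C)C1=NCCN1` carries an ethoxy group on the aromatic ring, and in a functional assay on CHO cells for agonist activity at Alpha-2C adrenergic receptor (Homo sapiens) (a higher number here means that more compound is needed for the effect, a lower number that less compound is needed), compound 3 gives 10000 nM, the highest number among the three compounds measured here. Compound 1 `CCc1ccccc1OC(C)C1=NCCN1` gives 100 nM, and compound 2 `C=C(C)c1ccccc1OC(C)C1=NCCN1` gives 115 nM; these two lie within the scatter of each other, with a 1.2-fold higher number from compound 1 to compound 2 (0.06 log units; within the scatter). Compound 3 stands far from both: there is a 100-fold higher number from compound 1 to compound 3 (2.00 log units; beyond the scatter) and an 87-fold higher number from compound 2 to compound 3 (1.94 log units; beyond the scatter).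

Compound 4 `CC(C)Oc1ccccc1OC(C)C1=NCCN1` differs from compound 3 by methyl in place of hydrogen on a saturated chain carbon bound to an oxygen on an aromatic ring and a saturated chain carbon. Neither of the large measured steps bears directly on this change: both concern replacing a carbon substituent on the aromatic ring with an oxygen-linked one, whereas compound 4 keeps the oxygen link of compound 3 and only extends the chain behind it. The small step between compound 1 and compound 2 varies a carbon substituent, not an alkoxy chain, and offers no guide either. Within the data shown here, with no measured step covering this kind of change, the expected step is no change at the digits printed from compound 3 to compound 4 (within the scatter), not beyond the scatter, in no firm direction. The estimate for compound 4 in this assay is 10000 nM, with a range from 2500 nM to 40000 nM.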

Compound 4, half-maximal effective concentration: 100 nM
Beside the measured number, compound 4's estimate is 100-fold (2.00 log units) above it; measured number outside the range, below it.
By their numbers in this assay, from the lowest: compounds 1, 4 and 2 (each within the scatter of the next); then compound 3.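

In this assay, the methyl on the saturated chain carbon, which turns ethoxy into isopropoxy, is by itself a large step (a 100-fold lower number from compound 3 to compound 4 (2.00 log units; beyond the scatter)), so one added carbon at this place decides the reading. The oxygen link as such therefore does not carry the high number: the earlier large steps from ethyl and from 1-methylethenyl held for ethoxy only, and isopropoxy reads the same as ethyl (no change at the digits printed from compound 1 to compound 4 (within the scatter)) and within the scatter of 1-methylethenyl (a 1.2-fold lower number from compound 2 to compound 4 (0.06 log units; within the scatter)). Among these four compounds ethoxy is thus the only group that stands apart, and the branching at this chain carbon, not the oxygen on the aromatic ring, separates compound 3 from compound 4.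

Nothing at hand gives a reason for this large step. The compounds shown leave open whether a propoxy chain, a cyclopropoxy group or a tert-butoxy group would read like ethoxy or like isopropoxy, and so whether the low number depends on the branch itself or on the size of the chain.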